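Nitro to phenylsulfonyl on the dimethyl core

The source may hold more compounds than are shown below. What is called first, only, known or untested is meant among the compounds shown, and "the series" means these compounds.

Measured so far in a functional assay with Cavia porcellus as the target; a higher number here means a weaker inhibitor, a lower number a stronger inhibitor:
compound 1 `CC1(C)CN(c2cccc[n+]2[O-])c2cc([N+](=O)[O-])ccc2O1` gives 74 nM
compound 2 `CC1(C(F)(F)F)CN(c2cccc[n+]2[O-])c2cc(S(=O)(=O)c3ccccc3)ccc2O1` gives 0.54 nM
compound 3 `O=[N+]([O-])c1ccc2c(c1)N(c1cccc[n+]1[O-])CC(C(F)F)(C(F)F)O2` gives 7 nM

In this assay compound 1 stands at the highest of the three numbers. Compound 3 lies an appreciable way below it, beyond the scatter, and compound 2 lies far below it, also beyond the scatter, so compound 1 is the weakest inhibitor of the three.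

The next compound is compound 4 `CC1(C)CN(c2cccc[n+]2[O-])c2cc(S(=O)(=O)c3ccccc3)ccc2O1`. It is obtained from compound 1 by one change, (phenylsulfonyl in place of nitro on an aromatic carbon). Among the compounds with values here, no measured pair shows this step on its own, so its size has to be inferred. Compound 2, which carries the phenylsulfonyl group, gives 0.54 nM, the lowest number of the set, which points to the step in this assay going downward, most likely well beyond the scatter. An estimate for compound 4 is 6 nM, within 1.5 nM to 25 nM. That estimate corresponds to an expected step of a 12-fold lower number from compound 1 to compound 4 (1.09 log units; beyond the scatter).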

Compound 4, half-maximal inhibitory concentration: 4.1 nM
For compound 4 the middle estimate is 1.5-fold (0.17 log units) above the measured one; measured number inside the range.
By their numbers in this assay, from the lowest: compound 2; then compounds 4 and 3 (each within the scatter of the next); then compound 1.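

In this assay, the swap of nitro for phenylsulfonyl on an aromatic carbon can now be read on its own on the dimethyl core, as an 18-fold lower number from compound 1 to compound 4 (1.26 log units; beyond the scatter), so this aromatic carbon strongly affects the read-out. The same new compound also isolates a change on a saturated ring carbon with phenylsulfonyl held fixed: methyl in place of trifluoromethyl gives a 7.6-fold higher number from compound 2 to compound 4 (0.88 log units; beyond the scatter), so the phenylsulfonyl step alone does not set the number seen for compound 2. Nothing available bears on why either step occurs.

Only the dimethyl core is shown with both nitro and phenylsulfonyl, so it remains open whether the step carries over to cores with trifluoromethyl or difluoromethyl on the saturated ring carbon. Also open, as far as these compounds go, is how a nitrile, a methylsulfonyl or a primary amide would read at this aromatic carbon.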